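The compounds below may be only part of what the source reports. "The series", "measured", "known", "first", "only" and "open" are said of these compounds alone.

Working notes on the series. Compound 3 `Oc1ccc(-c2cc(-c3ccncc3)nc(-c3cccc(Cl)c3)c2)cc1` stands without a number: in a functional assay on DU-145 cells (Homo sapiens) for cytotoxicity, read by CCK-8 assay and cell counting, with a stated time of 2 days (a higher number here means a weaker inhibitor, a lower number a stronger inhibitor), the entry for compound 3 reads "not determined" (no result reported). Compound 1 `Oc1ccc(-c2cc(-c3ccncc3)nc(-c3ccccc3Cl)c2)cc1` is in the same position, and in this assay the entry for compound 1 reads "not determined" (no result reported). The only figure in hand belongs to compound 2 `Oc1ccc(-c2cc(-c3cccnc3)nc(-c3cccc(Cl)c3)c2)cc1`, which in this assay gives 22900 nM, a weak value. Compound 4 `Oc1ccc(-c2cc(-c3ccccc3)nc(-c3cccc(Cl)c3)c2)cc1` differs from compound 3 in one place: phenyl in place of pyridin-4-yl on an aromatic carbon. For the measured compounds named here, with no number for compound 3, no step can be computed, and the size of the change in this assay is expected to stay within the scatter, neither clearly weaker nor stronger than the single value the series shows. For compound 4 the estimate in this assay is 22000 nM, with a range from 6000 nM to 80000 nM.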

Compound 4, half-maximal inhibitory concentration: 5360 nM
Compound 4: the middle estimate sits 4.1-fold (0.61 log units) above what was measured; measured number outside the range, below it.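

In this assay, for the compounds shown here, the position next to the ring nitrogen responds to the aryl group it carries: phenyl in place of pyridin-3-yl gives a 4.3-fold lower number from compound 2 to compound 4 (0.63 log units; beyond the scatter) and is the first readable step. The step from pyridin-4-yl to phenyl cannot be read, as compound 3 has no single number. No data in hand account for the change.

Open, going by these compounds, is whether the ring nitrogen's place matters at all. Also open, on these data alone, is how an amine, a carboxylic acid or a short alkyl chain at this position would compare with phenyl.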